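This account rests on a few compounds, and the source may have more. Where it says the series, first, only, none or still open, it means among the compounds named here.

Working notes on the series.

Three compounds have numbers in a functional assay on cells for antagonist activity at D(4) dopamine receptor (Homo sapiens), read by TR-FRET and cAMP accumulation, with a stated time of 30 min; a higher number here means a weaker inhibitor, a lower number a stronger inhibitor. Compound 1 `Cc1cccc(NC(=O)CN2CCC(c3ccc(Cl)cc3)CC2)c1` gives 70200 nM in this assay. Compound 2 `O=C(CN1CCN(c2ccccn2)CC1)Nc1cccnc1` gives 86500 nM in this assay. Compound 3 `CCc1cccc(NC(=O)CN2CCN(c3ccc(Cl)cn3)CC2)c1` gives 7060 nM in this assay, the lowest of the three numbers; the gaps to compound 1 and to compound 2 are both beyond the scatter, so compound 3 is the strongest inhibitor of the three measured.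

The next compound is compound 4 `CCc1cccc(NC(=O)CN2CCN(c3ccccn3)CC2)c1`. Compared with compound 3 the change is hydrogen in place of chloro on an aromatic carbon, read one bond further out as 5-chloropyridin-2-yl to pyridin-2-yl. Among the compounds with values here, no measured pair shows this change by itself, so its size is not known here; the other two compounds differ from compound 3 in more than this one place and give no clean comparison.

The expectation for compound 4 is a moderate rise in this assay, a step of a 2.5-fold higher number from compound 3 to compound 4 (0.41 log units; beyond the scatter) that may or may not clear the scatter. Compound 4 is estimated at 18000 nM in this assay, with a range from 6000 nM to 55000 nM.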

Compound 4, half-maximal inhibitory concentration: 1310 nM
The estimate for compound 4 lay 14-fold (1.14 log units) above the measured number; the whole stated range lies above it.
By their numbers in this assay, from the lowest: compound 4; then compound 3; then compounds 1 and 2 (each within the scatter of the next).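

Removing the chloro from the position two atoms from the ring nitrogen gives a 5.4-fold lower number from compound 3 to compound 4 (0.73 log units; beyond the scatter) in this assay; the chloro is therefore not needed for inhibition here, and with the 3-ethylphenyl amide the unsubstituted pyridin-2-yl compound is the stronger inhibitor. The series also gains its first reading on the amide side: 3-ethylphenyl in place of pyridin-3-yl on the amide-type nitrogen, with the rest of the molecule unchanged, gives a large step, a 66-fold lower number from compound 2 to compound 4 (1.82 log units; beyond the scatter). Nothing available explains either step.

On these data alone, only hydrogen and chloro are compared at this ring position, so the outcome with fluoro, methoxy or an amine there remains open. As far as these compounds go, on the amide side, the effect of a longer chain in place of the ethyl group, or of a carboxylic acid on that ring, also remains open.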